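The compounds below may be only part of what the source reports. "The series", "measured", "known", "first", "only" and "open" are said of these compounds alone.

Measured so far:
- compound 2, `CN(C)CCn1cnnc1-c1cc(Oc2ccc(NC(=O)N/N=C/c3ccc(Cl)cc3)cc2F)ccn1`: 1870 nM
- compound 1, `CN(C)CCn1cnnc1-c1cc(Oc2ccc(NC(=O)N/N=C/c3cccc(O)c3)cc2F)ccn1`: "not determined" (no result reported)
- compound 3, `CN(C)CCn1cnnc1-c1cc(Oc2ccc(NC(=O)N/N=C/c3ccc(O)cc3)cc2F)ccn1`: "not determined" (no result reported)

These three compounds share one core, differing only in the aromatic group attached to the carbon that carries a double bond to nitrogen. For the measured compounds named here, in an ADME assay on WI-38 cells (Homo sapiens) for cytotoxicity, read by MTT assay, with a stated time of 72 h (on this read-out lower numbers stand for stronger inhibition and higher numbers for weaker inhibition), compound 2 gives 1870 nM, and this is the only number available, since compound 1 and compound 3 came back without a result. Compound 4, `COc1cc(/C=N/NC(=O)Nc2ccc(Oc3ccnc(-c4nncn4CCN(C)C)c3)c(F)c2)ccc1O`, has not yet been tested.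

The change from compound 2 to compound 4 is 4-hydroxy-3-methoxyphenyl in place of 4-chlorophenyl on a carbon with a double bond to nitrogen. Going by the values given here, nothing measured shows how this swap moves the read-out, because no two compounds with numbers differ in a single place. Among the compounds with values here, with only one number to start from, the expected step from compound 2 to compound 4 is a small weakening of the effect, a 1.3-fold higher number from compound 2 to compound 4 (0.13 log units; within the scatter), which is roughly of the size of ordinary scatter. On that basis compound 4 is expected to give about 2500 nM in this assay, with a plausible range from 900 nM to 7000 nM.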

Compound 4, half-maximal inhibitory concentration: 5320 nM
Beside the measured number, compound 4's estimate is 2.1-fold (0.33 log units) below it; the measured number falls inside the stated range.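

For the compounds shown here, this is the first measured step at this position, the aromatic group on a carbon with a double bond to nitrogen. In this assay, 4-hydroxy-3-methoxyphenyl in place of 4-chlorophenyl gives a 2.8-fold higher number from compound 2 to compound 4 (0.45 log units; beyond the scatter), so this modest step shows that the group at this position can move the read-out towards weaker inhibition by more than ordinary scatter. Nothing available here explains the shift.

Going by these compounds, compound 1 and compound 3 carry a hydroxyl group on that ring without the methoxy group, but both came back without a number, so their steps cannot be read and the separate shares of the hydroxyl and the methoxy remain unknown. Also open, on these data alone, is how the read-out would respond to an amine or a carboxylic acid on that ring.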